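One Side-Chain Exchange Among Three Measured Relatives

This account rests on a few compounds, and the source may have more. Where it says the series, first, only, none or still open, it means among the compounds named here.

Of the compounds shown here, three have been measured in a functional assay on the whole organism (strain albino) for inhibition, with Rattus norvegicus as the target, read by paw edema, with a stated time of 2 h, at a dose of 0.28 mmol/kg by the oral route; a lower number here means less inhibition, a higher number more inhibition at the dose given (going by the name of the read-out). Compound 1, `C=CCn1c(SC/C(=N\O)c2ccccc2)nnc1-c1ccc(OC)c(OC)c1`, gives 57% in this assay. Compound 2, `COc1ccc(-c2nnc(SC/C(=N/O)c3ccccc3)n2-c2ccccc2)cc1`, gives 63% in this assay, and compound 3, `CCn1c(SCC(=O)c2ccccc2)nnc1-c1ccc(OC)cc1`, gives 60% in this assay. Compound 1 holds the lowest of the three numbers, yet its nearest neighbour compound 3 and its furthest neighbour compound 2 both stand within the usual scatter of it, so the three values show no separation that can be read as a difference.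

Compound 4, `C=CCn1c(SCC(=O)c2ccccc2)nnc1-c1ccc(OC)c(OC)c1`, has not yet been measured. It differs from compound 1 at one place: a group of 8 heavy atoms (7 carbon, 1 oxygen; one six-membered aromatic ring of carbon only) in place of a group of 9 heavy atoms (7 carbon, 1 nitrogen, 1 oxygen; one six-membered aromatic ring of carbon only), on a saturated chain carbon bound to a sulfur. The benzoyl group thus enters on the saturated chain carbon bound to a sulfur, where compound 1 carries the group of nine heavy atoms.

Among the compounds with values here, no step between two measured compounds isolates this exchange, so its size is not known from the data. Compound 3 already carries a benzoyl group on the same kind of chain carbon and sits within the scatter of compound 1, which gives no sign that the exchange moves the number beyond the scatter in either direction. The step from compound 1 to compound 4 is therefore expected to be a number 3 percentage points higher from compound 1 to compound 4 (within the scatter), within the scatter. Compound 4 is estimated to give 60% in this assay, with a range from 50% to 70%.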

Compound 4, a percentage reported as inhibition, in the whole organism at one dose (the size of the read-out at that dose, not a potency): 63%
Compound 4: the middle estimate sits 3 percentage points below what was measured, and the stated range covers the measured number.
By their numbers in this assay, from the lowest: compounds 1, 3, 2 and 4 (each within the scatter of the next).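

In this assay, the exchange of the group of 9 heavy atoms for benzoyl, on a saturated chain carbon bound to a sulfur, gives a number 6 percentage points higher from compound 1 to compound 4 (within the scatter), and this is the only step shown that isolates this place with the rest of the molecule held fixed. The earlier compounds shown here could only hint at this, since each of them differs from the others in more than one place, whereas this pair shows directly that the exchange, which removes the hydrogen-bond donor present in the departing group, leaves the read-out within the usual scatter at this dose. No measurement on hand bears on why the step has this size.

The compounds shown leave open whether an amine, a carboxylic acid or a longer chain on a saturated chain carbon bound to a sulfur would give a step beyond the scatter. They also leave open whether the benzoyl exchange would stay within the scatter at other doses or with other groups on the shared core, as a single pair at a single dose cannot settle either point.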